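Swapping a Pyridine for a Pyrimidine on the Shared Core

This account rests on a few compounds, and the source may have more. Where it says the series, first, only, none or still open, it means among the compounds named here.

Of the compounds shown here, two have been measured so far in an in vitro assay on BHK cells for displacement of a labelled ligand from Alpha-1A adrenergic receptor (Bos taurus), read by scintillation counting, with a stated time of 20 min; a lower number here means a stronger inhibitor, a higher number a weaker inhibitor. Compound 1 `CN1CCC(c2cn(-c3ccncc3)c3ccc(-c4ccncc4)cc23)CC1` gives 24 nM in this assay. Compound 2 `CN1CCC(c2cn(-c3ccncc3)c3ccc(-c4cccnc4)cc23)CC1` carries pyridin-3-yl in place of pyridin-4-yl on an aromatic carbon and gives 22 nM. The step of a 1.1-fold lower number from compound 1 to compound 2 (0.04 log units; within the scatter) lies within the scatter, so these two numbers cannot be told apart. Compound 2 thus holds the lowest of the two numbers seen, with compound 1 at a number that differs from it only within the scatter.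

Compound 3 `CN1CCC(c2cn(-c3ccncc3)c3ccc(-c4cncnc4)cc23)CC1` is not yet measured. It differs from compound 2 in one place: pyrimidin-5-yl in place of pyridin-3-yl on an aromatic carbon. Going by the values given here, the one measured step that bears on this change is a 1.1-fold lower number from compound 1 to compound 2 (0.04 log units; within the scatter), in which a rearrangement of the single ring nitrogen within the same six-membered aromatic ring left the number within the scatter. Adding a second ring nitrogen is a change of a similar kind, and no measured step shows a larger effect. Compound 3 is therefore expected to show a 1.4-fold higher number from compound 2 to compound 3 (0.13 log units; within the scatter), a step within the scatter and without a clear direction. Compound 3 is estimated at 30 nM, with a range from 12 nM to 75 nM.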

Compound 3, inhibition constant: 19 nM
For compound 3 the middle estimate is 1.6-fold (0.20 log units) above the measured one, within the range that was stated.
By their numbers in this assay, from the lowest: compounds 3, 2 and 1 (each within the scatter of the next).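

In this assay this aromatic carbon, para to a fused ring in the words of the computed description, now has a ring with 2 hetero atoms as well as rings with 1, and the numbers still cannot be told apart. Pyrimidin-5-yl in place of pyridin-3-yl gives a 1.2-fold lower number from compound 2 to compound 3 (0.06 log units; within the scatter), and pyrimidin-5-yl in place of pyridin-4-yl gives a 1.3-fold lower number from compound 1 to compound 3 (0.10 log units; within the scatter), so the second ring nitrogen shows no effect that rises out of the scatter against either pyridine, which the single step between the two pyridines could not show. No supporting measurement is available that would explain why these three groups read alike.

Still open, going by these compounds, is whether this carbon stays as undemanding when it carries something other than a nitrogen-containing aromatic ring, such as a plain phenyl ring, an amine or a carboxylic acid. All three compounds also keep the rest of the shared core unchanged, so these numbers say nothing about groups placed elsewhere on it.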